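Anilino to cyclohexylamino on the quinone-bearing core

The source may hold more compounds than are shown below. What is called first, only, known or untested is meant among the compounds shown, and "the series" means these compounds.

Measured compounds:
compound 1 `O=C1C(Nc2ccccc2)=CC(=O)c2c1nc1n2[C@H]2OC[C@@H](O)[C@H]2OC1`, 1830 nM
compound 2 `O=C1C=C(NC2CCCCC2)C(=O)c2c1nc1n2[C@H]2OC[C@@H](O)[C@H]2OC1`, > 8000 nM
compound 3 `O=C1C=C(NC2CCCC2)C(=O)c2c1nc1n2[C@H]2OC[C@@H](O)[C@H]2OC1`, > 8000 nM

Within the data shown here, in a functional assay on MGC-803 cells (Homo sapiens) for inhibition, read by sulforhodamine B assay (on this read-out lower numbers stand for stronger inhibition and higher numbers for weaker inhibition), compound 1 gives 1830 nM, the only number in the set. Compound 2 gives > 8000 nM, which is a limit of the assay and not a number. Compound 3 likewise gives > 8000 nM, again a limit. The step that the two limits leave unreadable from compound 2 to compound 3 is therefore unreadable. Compound 4 `O=C1C(NC2CCCCC2)=CC(=O)c2c1nc1n2[C@H]2OC[C@@H](O)[C@H]2OC1` is not yet measured; it differs from compound 1 by cyclohexyl in place of phenyl on an amine nitrogen. Among the measured compounds shown here, no measured step covers this exact change, so the expectation rests on the observation (the limit of > 8000 nM in this assay, at which 2 of the 3 values shown sit), where compound 2, which also carries a cyclohexyl on an amine nitrogen, sits. Compound 4 is therefore expected to lose potency, and may itself return only a limit. The expected step is a 2.7-fold higher number from compound 1 to compound 4 (0.44 log units; beyond the scatter). The estimate for compound 4 is 5000 nM, with a range from 1500 nM to 20000 nM.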

Compound 4, half-maximal inhibitory concentration: > 8000 nM
Compound 4: a limit, no number (the forecaster's own chance of this, stated with the estimate: 45%); middle value at least 1.6-fold (0.20 log units) away from the limit.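

In this assay, among these compounds, the anilino to cyclohexylamino change on the shared core gives an at least 4.3-fold higher number from compound 1 to compound 4 (0.64 log units; beyond the scatter), the first readable step at this amine nitrogen. Going by these compounds, compound 4 gives > 8000 nM, which is a limit of the assay and not a number, so the full size of the loss stays open. Phenyl and cyclohexyl carry the same count of heavy atoms, so this pair separates an aromatic ring from a non-aromatic ring at equal size, and only the phenyl compound stays off the limit: the limit of > 8000 nM in this assay, at which 3 of the 4 values shown sit.

The step from compound 2 to compound 3 cannot be read, and the limits give no order among the cycloalkyl compounds. Still open, on these data alone, is whether a benzylamino group, or a methoxy group or chlorine on the phenyl ring, would hold the potency of compound 1.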